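The compounds below may be only part of what the source reports. "The series", "measured", "known", "first", "only" and "open" are said of these compounds alone.

Compound 1 `CC(=O)Nc1ccc(Nc2ncnc3c2cnn3CC(=O)O)cc1`; compound 2 `O=C(O)Cn1ncc2c(Nc3ccc(NS(=O)(=O)c4ccc(Br)cc4)cc3)ncnc21`.

In a functional assay on cells (Homo sapiens) for inhibition, read by MTT assay, with a stated time of 72 h (a lower number here means a stronger inhibitor, a higher number a weaker inhibitor), compound 1 gives > 64 ug/mL, a limit of the assay and not a number. In this assay compound 2 gives > 64 ug/mL, likewise a limit. The step that the two limits leave unreadable from compound 1 to compound 2 is therefore unreadable. Compound 2 stands at the limit of > 64 ug/mL in this assay, at which 2 of the 2 values shown sit. Compound 3 `O=C(O)Cn1ncc2c(Nc3ccc(NC(=O)c4ccccc4)cc3)ncnc21` differs from compound 2 by benzoyl in place of (4-bromophenyl)sulfonyl on a nitrogen on an aromatic ring. For the measured compounds named here, since the only measured step is unreadable, no size for this assay can be taken from it, and compound 3 is expected to show no step beyond the scatter, a step that the limit leaves unreadable from compound 2 to compound 3. Compound 3 is expected at 100 ug/mL, between 40 ug/mL and 300 ug/mL, most likely again reported as a limit.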

Compound 3, half-maximal inhibitory concentration: > 100 ug/mL
Compound 3 was reported as a limit; the forecaster's own chance of this, stated with the estimate: 80%; the middle value sits exactly at the limit.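

In this assay compound 3 gives > 100 ug/mL, a limit and not a number. For the compounds shown here, no step among compound 1, compound 2 and compound 3 can be read. The compounds shown leave open whether acetyl, (4-bromophenyl)sulfonyl or benzoyl on the nitrogen makes any difference in this assay.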